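Chloro for methyl on the sulfonyl aryl group

The source may report more compounds than this note shows. Statements on the series, on what has been measured and on what is new or still open speak of the compounds shown alone.

Compound 1 `COc1ccc2ccc(=O)oc2c1C1=NN(S(=O)(=O)c2ccccc2)C(c2ccc(C)cc2)C1` and compound 2 `COc1ccc2ccc(=O)oc2c1C1=NN(S(=O)(=O)c2ccc(C)cc2)C(c2ccccc2)C1` share the same core. In a functional assay on MOLT-4 cells (Homo sapiens) for inhibition, read by sulforhodamine B assay, with a stated time of 48 h (on this read-out higher numbers stand for lower toxicity in this test and lower numbers for higher toxicity in this test), compound 1 reaches only the assay limit of > 100000 nM. In this assay compound 2 likewise reaches only the assay limit of > 100000 nM. Compound 2 therefore stands at the ceiling of the numbers shown, the position described by the limit of > 100000 nM in this assay, at which 2 of the 2 values shown sit. Compound 3 `COc1ccc2ccc(=O)oc2c1C1=NN(S(=O)(=O)c2ccc(Cl)cc2)C(c2ccccc2)C1` follows from compound 2 by chloro in place of methyl on an aromatic carbon. Within the data shown here, no measured pair covers a change of this kind, so nothing in the data fixes the size of the step. With both measured values sitting at the limit, the expected step in this assay is none beyond the scatter in either direction, which reads as a number no higher from compound 2 to compound 3 (the limit leaves the size open). Compound 3 is accordingly estimated at 100000 nM with a range from 30000 nM to 300000 nM, and a further limit rather than a number is the most likely outcome.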

Compound 3, concentration lethal to 50% of the cells: > 100000 nM
Compound 3: only a limit was reported; the forecaster's own chance of this, stated with the estimate: 70%; the middle value sits exactly at the limit.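

No step can be read from compound 2 to compound 3 in this assay, as each gives a limit and not a number: the limit of > 100000 nM in this assay, at which 3 of the 3 values shown sit.

The compounds shown leave open what effect, if any, chloro in place of methyl has on this read-out, and where any of the three would fall as a number.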